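Carbonate to carbamate on an azido-thymidine side chain

The compounds below may be only part of what the source reports. "The series", "measured", "known", "first", "only" and "open" are said of these compounds alone.

Measured so far:
Compound 1, `Cc1cn(C2CC(N=[N+]=[N-])C(COC(=O)OCCCC(=O)O)O2)c(=O)[nH]c1=O`: -0.55
Compound 2, `Cc1cn(C2CC(N=[N+]=[N-])C(COC(=O)NCCCC(=O)OC(C)(C)C)O2)c(=O)[nH]c1=O`: 0.88
Compound 3, `Cc1cn(C2CC(N=[N+]=[N-])C(COC(=O)OCCCN)O2)c(=O)[nH]c1=O`: -0.93

In a physicochemical assay for lipophilicity (a lower number here means a more polar compound, a higher number a more lipophilic compound), compound 3 gives the lowest of the three numbers. Within the data shown here, its nearest neighbour is compound 1, and the one measured step, a number 0.38 log units lower from compound 1 to compound 3 (beyond the scatter), separates these two. Compound 2 stands furthest away, with its value far above that of compound 3, but compound 2 differs from the others in more than one place, so its number can only be taken as it stands.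

Compound 4, `Cc1cn(C2CC(N=[N+]=[N-])C(COC(=O)NCCCN)O2)c(=O)[nH]c1=O`, has not yet been measured. It differs from compound 3 in one place: (3-aminopropyl)amino in place of 3-aminopropoxy on a carbonyl carbon. Among the measured compounds shown here, no measured step bears directly on this exchange; the single step known, from compound 1 to compound 3, alters the end of the chain, not the carbonyl carbon. What can be said is that the part entering carries one more hydrogen-bond donor and one fewer acceptor than the part leaving, as counted above.

On that basis the expectation for compound 4 in this assay is a small step downward, a number 0.27 log units lower from compound 3 to compound 4 (within the scatter), possibly no larger than the scatter. Compound 4 is therefore estimated at -1.2, with a range from -1.8 to -0.7.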

Compound 4, partition coefficient: -1.19
Estimate against measurement, compound 4: 0.01 log units below; the range from low to high includes it.
By their numbers in this assay, from the lowest: compounds 4 and 3 (each within the scatter of the next); then compound 1; then compound 2.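

Swapping 3-aminopropoxy for (3-aminopropyl)amino on the carbonyl carbon gives, in this assay, a number 0.26 log units lower from compound 3 to compound 4 (within the scatter), so with the amino group present, this exchange at this position cannot be told apart from the ordinary spread of repeated measurements. Much more separates the compounds when the other group on the chain differs: amino in place of tert-butoxycarbonyl on a saturated chain carbon gives a number 2.07 log units lower from compound 2 to compound 4 (beyond the scatter), the largest step in this set, while (3-aminopropyl)amino in place of 3-carboxypropoxy on the carbonyl carbon gives a number 0.64 log units lower from compound 1 to compound 4 (beyond the scatter), a step that replaces the carboxy group along with the linking oxygen. No separate measurement is available that would explain any of these differences.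

Going by these compounds, whether the exchange on the carbonyl carbon would stay equally small with a carboxylic acid in place of the amino group, or with a tert-butyl ester on both linkers, remains open. So does its size on a longer chain, or with a methyl group on the amide-type nitrogen.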